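A few compounds are considered here, and "the series" means these few. Any claim that something is new, unique, unknown or untested is made for them only; others in the source may bear on it.

Compound 1 `O=C(Nc1cccc(-n2cc(-c3ccncc3)c(-c3ccc(Cl)c(O)c3)n2)c1)Nc1cccc(C(F)(F)F)c1` gives > 32500 nM in a functional assay on HCC 2998 cells (Homo sapiens) for inhibition, read by sulforhodamine B assay, with a stated time of 48 h (on this read-out higher numbers stand for weaker inhibition of growth and lower numbers for stronger inhibition of growth), which is a limit of the assay rather than a number (the limit of > 32500 nM in this assay, at which 1 of the 3 values shown sits).
Compound 2 `COc1cc(-c2nn(-c3cccc(NC(=O)c4cccc(C(F)(F)F)c4)c3)cc2-c2ccncc2)ccc1Cl` gives 17600 nM in this assay.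
Compound 3 `O=C(Nc1cccc(-n2cc(-c3ccncc3)c(-c3ccc(Cl)c(O)c3)n2)c1)Nc1cc(C(F)(F)F)cc(C(F)(F)F)c1` gives 2410 nM in this assay.

Compound 2 holds the highest of the two measured numbers; its nearest neighbour, compound 3, sits beyond the scatter below it. Compound 4 `COc1cc(-c2nn(-c3cccc(NC(=O)Nc4ccc(Cl)c(C(F)(F)F)c4)c3)cc2-c2ccncc2)ccc1Cl` differs from compound 2 by (4-chloro-3-(trifluoromethyl)phenyl)amino in place of 3-(trifluoromethyl)phenyl on a carbonyl carbon. Within the data shown here, no measured step makes exactly this change. Among the measured compounds shown here, the only measured step, an at least 13-fold lower number from compound 1 to compound 3 (1.12 log units; beyond the scatter), adds a trifluoromethyl to an aryl urea and is large, yet compound 1, itself a urea with a single trifluoromethyl, reaches only a limit. A gain is therefore plausible but uncertain. Compound 4 is expected to give 8000 nM, within 2000 nM to 40000 nM. This corresponds to an expected step of a 2.2-fold lower number from compound 2 to compound 4 (0.34 log units; beyond the scatter).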

Compound 4, concentration for total growth inhibition: 7300 nM
Estimate against measurement, compound 4: 1.1-fold (0.04 log units) above; the measured number falls inside the stated range.
By their numbers in this assay, from the lowest: compound 3; then compound 4; then compound 2. At a limit, above all of these: compound 1.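

In this assay, the only step shown at the carbonyl carbon gives a 2.4-fold lower number from compound 2 to compound 4 (0.38 log units; beyond the scatter), a modest gain that lies beyond the scatter. Here (4-chloro-3-(trifluoromethyl)phenyl)amino in place of 3-(trifluoromethyl)phenyl brings in both a nitrogen and a chlorine, and this one step does not tell which of the two carries the gain. No measurement shown gives a reason for it. From the compounds shown here alone, it remains open whether a bromine or a nitrile in place of that chlorine would keep the gain. Going by these compounds, it also remains open whether the urea of compound 4 would keep it with no chlorine at all.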